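A few compounds are considered here, and "the series" means these few. Any claim that something is new, unique, unknown or untested is made for them only; others in the source may bear on it.

Compound 1 `CN(CCCNS(=O)(=O)c1cc(C(F)(F)F)cc(C(F)(F)F)c1)Cc1ccccc1`: 33000 nM
Compound 2 `O=S(=O)(NCCCNCc1cccc2ccccc12)c1cc(C(F)(F)F)cc(C(F)(F)F)c1`: 2800 nM

Both numbers come from a functional assay on MIA PaCa-2 cells (Homo sapiens) for inhibition, read by MTT assay, with a stated time of 72 h; on this read-out higher numbers stand for weaker inhibition of growth and lower numbers for stronger inhibition of growth. Of the two, compound 2 holds the lower number, and compound 1 sits far higher, a gap well beyond the usual scatter. Compound 3 `O=S(=O)(NCCCNCc1cccc(Cl)c1)c1cc(C(F)(F)F)cc(C(F)(F)F)c1` differs from compound 2 in one place: 3-chlorophenyl in place of naphthalen-1-yl on a saturated chain carbon bound to an amine nitrogen. Among the compounds with values here, no measured pair shows this exact change, so its effect is uncertain. The change is expected to raise the number moderately, by about a 2.1-fold higher number from compound 2 to compound 3 (0.33 log units; beyond the scatter). Compound 3 is therefore estimated at 6000 nM, with a likely range from 2000 nM to 20000 nM.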

Compound 3, concentration for 50% growth inhibition: 4400 nM
Compound 3: the middle estimate sits 1.4-fold (0.13 log units) above what was measured, within the range that was stated.
By their numbers in this assay, from the lowest: compounds 2 and 3 (each within the scatter of the next); then compound 1.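

In this assay, 3-chlorophenyl in place of naphthalen-1-yl gives a 1.6-fold higher number from compound 2 to compound 3 (0.20 log units; within the scatter), so at this position one aromatic ring of carbon serves as well as two. (3-Chlorobenzyl)amino in place of benzyl(methyl)amino gives a 7.5-fold lower number from compound 1 to compound 3 (0.88 log units; beyond the scatter), but this swap removes the methyl and adds the chlorine together, so their shares cannot be separated. No data here explain either step.

Open, on these data alone, is whether a plain benzylamino group would sit nearer compound 1 or compound 3. Also open, as far as these compounds go, is how a longer chain would affect growth inhibition.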